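Changing One Side Chain in a Cytotoxic Series

The source may report more compounds than this note shows. Statements on the series, on what has been measured and on what is new or still open speak of the compounds shown alone.

Measured in a functional assay on G-361 cells (Homo sapiens) for cytotoxicity, read by fluorescence, with a stated time of 72 h; on this read-out higher numbers stand for weaker inhibition and lower numbers for stronger inhibition:
- compound 1 `CSc1nc(NCc2ccc(-c3ccccn3)cc2)c2[nH]nc(C(C)C)c2n1`: 1400 nM
- compound 2 `CC(C)c1n[nH]c2c(NCc3ccc(-c4ccccn4)cc3)nc(NCC(C)(C)O)nc12`: 48 nM
- compound 3 `CC(C)c1n[nH]c2c(NCc3ccc(-c4ccccn4)cc3)nc(N[C@@H]3CCCC[C@H]3N)nc12`: 477 nM

Compound 3 lies in the middle of these three values, below compound 1 and above compound 2. Compound 4 `CC(C)c1n[nH]c2c(NCc3ccc(-c4ccccn4)cc3)nc(NCCN(C)C)nc12` differs from it in one group, on a nitrogen on an aromatic ring: 2-(dimethylamino)ethyl in place of 2-aminocyclohexyl on a nitrogen on an aromatic ring. For the measured compounds named here, three measured steps bear on this group. Replacing methylsulfanyl gave a large fall with 2-hydroxy-2-methylpropyl (a 29-fold lower number from compound 1 to compound 2 (1.46 log units; beyond the scatter)) and a modest fall with 2-aminocyclohexyl (a 2.9-fold lower number from compound 1 to compound 3 (0.47 log units; beyond the scatter)). Exchanging those two groups gave a modest rise (a 9.9-fold higher number from compound 2 to compound 3 (1.00 log units; beyond the scatter)). The new chain has no ring, like that of compound 2 (48 nM), but carries a nitrogen, like the group of compound 3 (477 nM), so a value between these two is expected. A modest fall is therefore expected (a 2.4-fold lower number from compound 3 to compound 4 (0.38 log units; beyond the scatter)). Compound 4 is estimated at 200 nM (expected range 55 nM to 700 nM).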

Compound 4, half-maximal inhibitory concentration: 640 nM
The estimate for compound 4 lay 3.2-fold (0.51 log units) below the measured number, within the range that was stated.
By their numbers in this assay, from the lowest: compound 2; then compounds 3 and 4 (each within the scatter of the next); then compound 1.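

In this assay, exchanging the ring-bearing 2-aminocyclohexyl for the open-chain 2-(dimethylamino)ethyl gives no clear change (a 1.3-fold higher number from compound 3 to compound 4 (0.13 log units; within the scatter)), so the ring and its 2 defined stereocentres are not needed to hold this level. Placing (dimethylamino)methyl where 1-hydroxy-1-methylethyl stood gives a large rise (a 13-fold higher number from compound 2 to compound 4 (1.12 log units; beyond the scatter)), while (2-(dimethylamino)ethyl)amino in place of methylsulfanyl gives only a modest fall (a 2.2-fold lower number from compound 1 to compound 4 (0.34 log units; beyond the scatter)). No measurement shown here accounts for these differences.

Going by these compounds, whether the low number of compound 2 depends on its hydroxyl or on its branched carbon chain stays open. So does how a 2-hydroxyethyl or 2-aminoethyl chain on the same nitrogen would compare.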